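Thiourea Aryl Swap in a Cell Antiproliferation Series

The compounds below may be only part of what the source reports. "The series", "measured", "known", "first", "only" and "open" are said of these compounds alone.

Compound 1, `NC(=O)c1c(NC(=O)c2cccc([N+](=O)[O-])c2)sc2c1CCN(Cc1c(Cl)cccc1Cl)C2`: 13500 nM
Compound 2, `NC(=O)c1c(NC(=O)c2ccccc2Cl)sc2c1CCN(C(=S)Nc1cccc3ccccc13)C2`: 20700 nM

In a functional assay on MKN-74 cells (Homo sapiens) for antiproliferative activity, with a stated time of 24 h (a lower number here means a stronger inhibitor, a higher number a weaker inhibitor), compound 1 gives 13500 nM and compound 2 gives 20700 nM. Compound 2 carries the higher of the two numbers, but its distance from compound 1 lies within the scatter, so the two cannot be put in order on these data. Compound 3, `COc1ccc(NC(=S)N2CCc3c(sc(NC(=O)c4ccccc4Cl)c3C(N)=O)C2)cc1`, differs from compound 2 in one place: 4-methoxyphenyl in place of naphthalen-1-yl on an amide-type nitrogen. Among the compounds with values here, no measured pair shows a change of this kind, so nothing in the data fixes its size or direction. Both measured compounds sit in the same weak range, and this change is expected to leave compound 3 near compound 2, with no step beyond the scatter. Compound 3 is therefore expected to give 25000 nM, within a range from 8000 nM to 80000 nM. The expected step is a 1.2-fold higher number from compound 2 to compound 3 (0.08 log units; within the scatter).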

Compound 3, half-maximal inhibitory concentration: 19600 nM
Estimate against measurement, compound 3: 1.3-fold (0.11 log units) above, and the stated range covers the measured number.
By their numbers in this assay, from the lowest: compounds 1, 3 and 2 (each within the scatter of the next).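

In this assay, within the data shown here, the swap of naphthalen-1-yl for 4-methoxyphenyl on the amide-type nitrogen gives a 1.1-fold lower number from compound 2 to compound 3 (0.02 log units; within the scatter) and is the first comparison that isolates a single place. It shows that, at this position on the thiourea, going from two six-membered aromatic rings to one and bringing in a methoxy oxygen leaves no change that can be read in this cell assay. Nothing available explains why the number holds through this swap.

The compounds shown leave open whether a non-aromatic group at this nitrogen, such as a cyclohexyl ring or a short alkyl chain, would give a step beyond the scatter. They also leave open what an amine or a carboxylic acid on the phenyl ring would do.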